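From 4-methoxyphenyl to 2-methoxyphenyl on a shared core

A few compounds are considered here, and "the series" means these few. Any claim that something is new, unique, unknown or untested is made for them only; others in the source may bear on it.

Compound 1 `COc1ccc(-c2ncnn2-c2cc(OC)c(OC)c(OC)c2)cc1` is the reference point for this comparison. Within the data shown here, in a functional assay on HL-60 cells (Homo sapiens) for antiproliferative activity, read by MTT assay, with a stated time of 72 h (a lower number here means a stronger inhibitor, a higher number a weaker inhibitor), compound 1 gives 120 nM, the only exact number available so far. Its close relative compound 2 `COc1cc(-n2ncnc2-c2ccc(OC(F)(F)F)cc2)cc(OC)c1OC` gives only a limit, > 10000 nM.

Among the measured compounds shown here, the one measured step is an at least 83-fold higher number from compound 1 to compound 2 (1.92 log units; beyond the scatter). It is a large loss of activity, and it comes from altering the methoxy group on the phenyl ring while that group stays in place.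

Compound 3 `COc1ccccc1-c1ncnn1-c1cc(OC)c(OC)c(OC)c1` has the same atoms as compound 1, joined differently: 2-methoxyphenyl in place of 4-methoxyphenyl on an aromatic carbon. For the measured compounds named here, the methoxy group itself survives here, but its position on the phenyl ring changes, and no measured step yet covers such a move. Going by the values given here, the step to compound 2 is therefore only a loose guide, but it is the sole evidence that changes to this group can matter.

In this assay the estimated change is a 13-fold higher number from compound 1 to compound 3 (1.10 log units; beyond the scatter), a weakening expected to be smaller than the measured step. Compound 3 is estimated at 1500 nM, with the result expected between 200 nM and 10000 nM.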

Compound 3, half-maximal inhibitory concentration: > 10000 nM
Compound 3: only a limit was reported; the forecaster's own chance of this, stated with the estimate: 25%; middle value at least 6.6-fold (0.82 log units) away from the limit.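

Moving the methoxy group, with no atom gained or lost, is enough to change the result: in this assay, going from 4-methoxyphenyl to 2-methoxyphenyl gives an at least 83-fold higher number from compound 1 to compound 3 (1.92 log units; beyond the scatter). For compound 3, the value > 10000 nM is a limit of the assay and not an exact number. Compound 2 had shown only that altering the methoxy group in place matters, whereas compound 3 shows that the position of an unaltered methoxy group on the phenyl ring matters as well, leaving compound 1 as the only one of the three with an exact value: the limit of > 10000 nM in this assay, at which 2 of the 3 values shown sit.

Since both changes from compound 1 end at a limit, the compounds shown cannot tell how large either loss really is, or whether one is worse than the other. They also leave open whether any other group on the phenyl ring, such as a hydroxyl group or an amine in place of the methoxy group of the 4-methoxyphenyl, would keep the activity of compound 1.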